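A few compounds are considered here, and "the series" means these few. Any claim that something is new, unique, unknown or untested is made for them only; others in the source may bear on it.

Measured compounds:
- compound 1 `CN1CCC[C@@H]1Cn1nc(Cc2cccc(F)c2)c2ccccc2c1=O`: 398 nM
- compound 2 `CN(C)CCn1nc(Cc2ccc(Cl)cc2)c2ccccc2c1=O`: 200 nM
- compound 3 `O=c1c2ccccc2c(Cc2ccc(Cl)cc2)nn1C[C@H]1CCCN1CCCCCc1ccc(OCCCN2CCCCCC2)cc1`: 50.1 nM

All three compounds share the same core and were tested in an assay for binding affinity to Alpha-1B adrenergic receptor (Homo sapiens); on this read-out lower numbers stand for stronger inhibition and higher numbers for weaker inhibition. Compound 1 gives 398 nM, the highest of the three numbers. The nearest number is that of compound 2, and the gap between compound 1 and compound 2 lies within the usual scatter of this assay, so the two cannot be told apart. The gap from compound 1 to compound 3 is far wider and lies well beyond the scatter, so compound 3 does bind more strongly than compound 1.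

Compound 4 `CN1CCC[C@@H]1Cn1nc(CCc2ccccc2)c2ccccc2c1=O` has not yet been measured. It differs from compound 1 in a single place: benzyl in place of 3-fluorophenyl on a saturated chain carbon bound to an aromatic carbon. The substituent that carries the aromatic ring is thus one carbon longer and loses its fluorine. For the measured compounds named here, no measured pair among the three compounds shows this kind of change, so there is no direct precedent to lean on. With the smallest change in the set, the expectation for compound 4 is a step of a 1.3-fold higher number from compound 1 to compound 4 (0.10 log units; within the scatter) in this assay, no further than the scatter allows. Compound 4 is therefore estimated at 500 nM, with a range from 150 nM to 1600 nM.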

Compound 4, inhibition constant: 200 nM
The estimate for compound 4 lay 2.5-fold (0.40 log units) above the measured number; the range from low to high includes it.
By their numbers in this assay, from the lowest: compound 3; then compounds 2, 4 and 1 (each within the scatter of the next).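

For the compounds shown here, this is the first pair in the set that differs in one place only: going from 3-fluorobenzyl to phenethyl gives a 2.0-fold lower number from compound 1 to compound 4 (0.30 log units; within the scatter) in this assay, so the two compounds cannot be told apart. Going by these compounds alone, at this position, then, the aromatic ring can sit one carbon further out and lose its fluorine with no difference in binding that this measurement can resolve, which the earlier compounds, differing from each other in several places at once, could not show. Nothing measured here explains this result.

Since the extra carbon and the loss of the fluorine come together in this one step, the compounds shown leave open what each does alone, and a plain benzyl or a 3-fluorophenethyl group would be needed to pull the two apart. Also open, from the compounds shown here alone, is how far this tolerance extends, for instance to a longer chain such as 3-phenylpropyl, or to a carboxylic acid or an amine on the aromatic ring, as read in this assay.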